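The compounds below may be only part of what the source reports. "The series", "measured", "known", "first", "only" and "open" are said of these compounds alone.

Compound 1 `CC(C)=CCC/C(C)=C/CC1Cc2c(O)cc(=O)n(CCCO)c2CC1(C)C` gives 28.7% in a functional assay on PANC-1 cells (Homo sapiens) for inhibition, read by MTT assay, with a stated time of 24 h, tested at 10 uM; a lower number here means less inhibition, a higher number more inhibition at the concentration tested (going by the name of the read-out).
Compound 2 `CC(C)=CCC/C(C)=C/CC1Cc2c(OCC=C(C)C)cc(=O)n(CCCO)c2CC1(C)C` gives 30.3% in this assay.
Compound 3 `CC(C)=CCC/C(C)=C/CC1Cc2c(OCCCNC(=O)c3cccs3)cc(=O)n(CCCO)c2CC1(C)C` gives 72.8% in this assay.

Compound 3 stands highest of the three in this assay; the step of a number 44.1 percentage points higher from compound 1 to compound 3 (beyond the scatter) and the step of a number 42.5 percentage points higher from compound 2 to compound 3 (beyond the scatter) both separate it clearly from the other two, while the step of a number 1.6 percentage points higher from compound 1 to compound 2 (within the scatter) shows compound 1 and compound 2 to be indistinguishable within the scatter.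

Compound 4 `COc1ccc(NC(=O)Oc2cc(=O)n(CCCO)c3c2CC(C/C=C(\C)CCC=C(C)C)C(C)(C)C3)cc1` differs from compound 3 at one place: (4-methoxyphenyl)carbamoyl in place of 3-(((thiophen-2-yl)carbonyl)amino)propyl on an oxygen on an aromatic ring. Within the data shown here, no measured pair shows this change directly. What bears on it is that the 3-(((thiophen-2-yl)carbonyl)amino)propyl group, entering on the aromatic oxygen, produced large rises in the step of a number 44.1 percentage points higher from compound 1 to compound 3 (beyond the scatter) and the step of a number 42.5 percentage points higher from compound 2 to compound 3 (beyond the scatter). As far as these compounds go, compound 4 keeps a group of the same size, with one hydrogen-bond donor and two acceptors, on that oxygen, but the six-membered carbon-only ring and the carbamoyl link are untested, so the gain seen for compound 3 cannot simply be carried over. Compound 4 is therefore expected to land between compound 1 and compound 3, with a step of a number 17.8 percentage points lower from compound 3 to compound 4 (beyond the scatter) downward from compound 3. The estimate for compound 4 is 55%, with a range from 30% to 78%.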

Compound 4, a percentage reported as inhibition, at one concentration (the size of the read-out at that concentration, not a potency): 64.1%
Estimate against measurement, compound 4: 9.1 percentage points below; low and high end bracket the measured number.
By their numbers in this assay, from the lowest: compounds 1 and 2 (each within the scatter of the next); then compounds 4 and 3 (each within the scatter of the next).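

On the oxygen on an aromatic ring, the (4-methoxyphenyl)carbamoyl group raises the number in this assay by a large step over hydrogen (a number 35.4 percentage points higher from compound 1 to compound 4 (beyond the scatter)) and over 3-methylbut-2-en-1-yl (a number 33.8 percentage points higher from compound 2 to compound 4 (beyond the scatter)), so the large rise is no longer tied to the 3-(((thiophen-2-yl)carbonyl)amino)propyl group alone. Exchanging that group for the (4-methoxyphenyl)carbamoyl group gives a step that stays within the scatter (a number 8.7 percentage points lower from compound 3 to compound 4 (within the scatter)), although the five-membered aromatic ring gives way to a six-membered carbon-only ring and the link also changes, so at this one concentration the assay does not tell these two groups apart. Nothing at hand explains why these two groups raise the number while 3-methylbut-2-en-1-yl does not.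

The compounds shown leave open whether the aromatic ring, the carbonyl or the nitrogen-bearing link carries the rise, and whether a plain benzoyl group, a longer chain or a terminal amine on the same oxygen would keep it. Because each compound is read at a single concentration, they also leave open how the potencies of compound 3 and compound 4 compare.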